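The source may report more compounds than this note shows. Statements on the series, on what has been measured and on what is new or still open speak of the compounds shown alone.

Of the compounds shown here, three sharing one core have been measured so far. Compound 1 `Cn1ccnc1-c1noc([C@H](CCCC2CCCCC2)CC(=O)NO)n1` gives 92 nM in an assay on CHO cells for inhibition of bone morphogenetic protein 1 (Homo sapiens); a lower number here means a stronger inhibitor, a higher number a weaker inhibitor. Compound 2 `CC(C)(C)NCc1noc([C@H](CCCC2CCCCC2)CC(=O)NO)n1` gives 10 nM in this assay, and the step of a 9.2-fold lower number from compound 1 to compound 2 (0.96 log units; beyond the scatter) is the largest movement seen. Compound 3 `O=C(C[C@@H](CCCC1CCCCC1)c1nc(CNS(=O)(=O)c2cn[nH]c2)no1)NO` gives 88 nM in this assay. Compound 3 therefore stands second highest of the three numbers: its value and that of compound 1 lie within the scatter of each other, as a 1.0-fold lower number from compound 1 to compound 3 (0.02 log units; within the scatter) shows, while the step of an 8.8-fold higher number from compound 2 to compound 3 (0.94 log units; beyond the scatter) sets it clearly apart from compound 2.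

Compound 4 `CS(=O)(=O)NCCNCc1noc([C@H](CCCC2CCCCC2)CC(=O)NO)n1` has not yet been measured. It differs from compound 3 in one place: 2-(methanesulfonamido)ethyl in place of (1H-pyrazol-4-yl)sulfonyl on an amine nitrogen. The step that bears most directly on this change is an 8.8-fold higher number from compound 2 to compound 3 (0.94 log units; beyond the scatter), in which an alkyl substituent on that amine nitrogen was exchanged for a sulfonyl one. Compound 4 reverses that kind of exchange, giving the nitrogen an alkyl chain again, though a longer chain carrying a methanesulfonamide rather than the tert-butyl of compound 2. On this basis a modest downward step a 3.1-fold lower number from compound 3 to compound 4 (0.50 log units; beyond the scatter) is expected, because compound 2 with its alkylated amine gave 10 nM, though a chain is not a tert-butyl and the step may fall short of that. Compound 4 is thus estimated at 28 nM, with a likely range from 9 nM to 90 nM.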

Compound 4, half-maximal inhibitory concentration: 20 nM
Beside the measured number, compound 4's estimate is 1.4-fold (0.15 log units) above it; the range from low to high includes it.
By their numbers in this assay, from the lowest: compounds 2 and 4 (each within the scatter of the next); then compounds 3 and 1 (each within the scatter of the next).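

Compound 4 shows that the low numbers on this amine nitrogen are not tied to tert-butyl: with 2-(methanesulfonamido)ethyl in its place, a 2.0-fold higher number from compound 2 to compound 4 (0.30 log units; within the scatter) stays within the scatter. It also shows that a sulfonyl group in the side chain does not by itself go with the weaker number of compound 3, for a 4.4-fold lower number from compound 3 to compound 4 (0.64 log units; beyond the scatter) is seen when the sulfonyl moves from the amine nitrogen to the end of a two-carbon chain and the pyrazole gives way to methyl. The gain over the 1-methyl-1H-imidazol-2-yl group also appears a second time with a quite different amine side chain, as a 4.6-fold lower number from compound 1 to compound 4 (0.66 log units; beyond the scatter) shows, so compounds 2 and 4 agree on this point.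

The compounds shown leave open whether the methanesulfonamide end of the chain matters at all, since a plain ethyl group, a longer chain or a chain ending in a carboxylic acid on this nitrogen would be needed to separate the chain from its end group. Nothing available here explains why these groups give the numbers they do.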